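Expected Tolerability of Compound 4 in a Cell Toxicity Assay

The source may report more compounds than this note shows. Statements on the series, on what has been measured and on what is new or still open speak of the compounds shown alone.

Compound 1 `CC(C)C[C@H](NC(=O)OCC1CCC(F)(F)CC1)C(=O)N[C@H](C=O)C[C@@H]1CCNC1=O`: > 100000 nM
Compound 2 `CC(C)C[C@H](NC(=O)OC1CCCCC1)C(=O)N[C@H](C=O)C[C@@H]1CCNC1=O`: > 100000 nM
Compound 3 `CC(C)C[C@H](NC(=O)OCC1CCC(F)(F)CC1)C(=O)N[C@@H](C[C@@H]1CCNC1=O)C(O)S(=O)(=O)O`: > 100000 nM

In a toxicity assay on Huh-7 cells (Homo sapiens) for cytotoxicity (a higher number here means that more compound is tolerated, a lower number that less compound is tolerated), compound 1 gives > 100000 nM, which is a limit of the assay and not a number. Compound 2 reaches only the limit > 100000 nM. Compound 3 likewise stands at the limit > 100000 nM. All three values sit at the limit of > 100000 nM in this assay, at which 3 of the 3 values shown sit, so no difference among them can be read.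

Compound 2 differs from compound 1 by cyclohexyl in place of (4,4-difluorocyclohexyl)methyl on an oxygen next to a carbonyl group, and the step that the two limits leave unreadable from compound 1 to compound 2. The core of compound 3 differs from that of compound 1 by hydroxy(sulfo)methyl in place of formyl on a saturated chain carbon bound to an amide-type nitrogen and a saturated chain carbon. Compound 4 `CC(C)C[C@H](NC(=O)OC1CCCCC1)C(=O)N[C@@H](C[C@@H]1CCNC1=O)C(O)S(=O)(=O)O` carries the same change as compound 2 carries against compound 1, here on the core of compound 3: cyclohexyl in place of (4,4-difluorocyclohexyl)methyl on an oxygen next to a carbonyl group; the place is the same word for word in both pairs.

For compound 4 the expected step is a step that the limit leaves unreadable from compound 3 to compound 4, and this rests on a step that the two limits leave unreadable from compound 1 to compound 2 together with the limit of > 100000 nM in this assay, at which 3 of the 3 values shown sit, where every measured compound sits. Compound 4 is therefore estimated at 150000 nM, between 80000 nM and 400000 nM, most likely reported again as a limit rather than a number.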

Compound 4, half-maximal cytotoxic concentration: > 100000 nM
Compound 4 ended at the assay's limit; the forecaster's own chance of this, stated with the estimate: 85%; the middle value is on the limit's open side.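

No new step can be read for compound 4, since its steps from compound 3 and from compound 2 cannot be read, and all four compounds stand at one limit of the assay: the limit of > 100000 nM in this assay, at which 4 of the 4 values shown sit.

The compounds shown leave open how their tolerated concentrations compare in this assay and whether either change in structure alters them.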